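The compounds below may be only part of what the source reports. "The series", "measured", "known", "first", "only" and "open" are said of these compounds alone.

Within the data shown here, in a functional assay on HCT-15 cells (Homo sapiens) for inhibition, read by colorimetric assay and sulforhodamine B assay, with a stated time of 48 h (on this read-out higher numbers stand for weaker inhibition of growth and lower numbers for stronger inhibition of growth), compound 1 `CCCCCCCCCCCC[C@@H](O)[C@H]1CC[C@H]([C@H](O)CCCCCCCCCCNC(=O)c2ccoc2)O1` gives 100000 nM and compound 2 `CCCCCCCCCCCC[C@@H](O)[C@H]1CC[C@H]([C@H](O)CCCCCCCCCCNC(=O)c2ccsc2)O1` gives 38000 nM, the lower of the two numbers measured so far. Compound 3 `CCCCCCCCCCCC[C@@H](O)[C@H]1CC[C@H]([C@H](O)CCCCCCCCCCNC(=O)c2ccnn2C)O1` keeps the shared core and the amide of compound 2 and differs in one group: 1-methyl-1H-pyrazol-5-yl in place of thiophen-3-yl on a carbonyl carbon. In words, 1-methyl-1H-pyrazol-5-yl stands in place of thiophen-3-yl on a carbonyl carbon. Among the measured compounds shown here, only one measured step bears on this change: a 2.6-fold lower number from compound 1 to compound 2 (0.42 log units; beyond the scatter), where thiophen-3-yl replaced furan-3-yl on a carbonyl carbon. That step is modest, though beyond the scatter, and it is thin evidence, since no ring with two hetero atoms has yet been measured here. A step of similar size therefore seems the fair expectation. The direction is a judgement: compound 2 holds the lower number at 38000 nM, so a move back toward higher numbers seems likelier than a further drop. The estimate means a 2.1-fold higher number from compound 2 to compound 3 (0.32 log units; beyond the scatter), an expected modest move to a higher number. For compound 3 the estimated value is 80000 nM, with an expected range from 30000 nM to 180000 nM.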

Compound 3, concentration for 50% growth inhibition: 100000 nM
The estimate for compound 3 lay 1.3-fold (0.10 log units) below the measured number; the measured number falls inside the stated range.
By their numbers in this assay, from the lowest: compound 2; then compounds 1 and 3 (each within the scatter of the next).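

In this assay, the change shows that the lower number of compound 2 does not carry over to a ring with 2 hetero atoms: a 2.6-fold higher number from compound 2 to compound 3 (0.42 log units; beyond the scatter), when 1-methyl-1H-pyrazol-5-yl replaces thiophen-3-yl on the carbonyl carbon. The two rings without sulfur give the same reading, with no change at the digits printed from compound 1 to compound 3 (within the scatter), so on this carbonyl carbon a swap of hetero atoms does not by itself move the number, and among these three compounds only the thiophen-3-yl amide, compound 2, stands apart. The data give no measured reason for that difference, and the result rests on a single modest step at high concentrations.

On these data alone, whether a six-membered aromatic ring such as phenyl or pyridin-3-yl, or the isomeric thiophen-2-yl, would read like compound 2 or like compounds 1 and 3 remains open. Also open, as far as these compounds go, is how the number would respond if the amide were replaced by an ester, or if a carboxylic acid or an amine stood at the end of the chain in its place.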